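This account rests on a few compounds, and the source may have more. Where it says the series, first, only, none or still open, it means among the compounds named here.

Working notes on the series.

Three compounds share one core and are measured in an assay on HeLa cells with Bile acid receptor (Homo sapiens) as the target, read by a luciferase reporter, with a stated time of 24 h; a higher number here means that more compound is needed for the effect, a lower number that less compound is needed. Compound 1, `CC(C)(C)c1ccc(C(=O)NCc2ccc(S(N)(=O)=O)cc2)cc1`, gives 1400 nM. Compound 2, `CC(C)(C)c1ccc(C(=O)NCc2ccc(CCC(=O)O)cc2)cc1`, gives 350 nM. Compound 3, `COc1ccc(CNC(=O)c2ccc(C(C)(C)C)cc2)cc1`, gives 150 nM, the lowest of the three numbers: the nearest is compound 2 and the furthest compound 1, with steps of a 2.3-fold lower number from compound 2 to compound 3 (0.37 log units; beyond the scatter) and a 9.3-fold lower number from compound 1 to compound 3 (0.97 log units; beyond the scatter), and between the other two a 4.0-fold lower number from compound 1 to compound 2 (0.60 log units; beyond the scatter).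

Compound 4 is `CC(=O)Nc1ccc(CNC(=O)c2ccc(C(C)(C)C)cc2)cc1`. It differs from compound 3 by acetamido in place of methoxy on an aromatic carbon. The measured steps all concern exchanges at the same aromatic carbon, and each of them went from a group carrying a hydrogen-bond donor or a carboxylic acid toward the methoxy of compound 3, lowering the number each time; the change to compound 4 goes the opposite way, bringing in a group with a hydrogen-bond donor. A modest rise in this assay is therefore expected, of about a 2.7-fold higher number from compound 3 to compound 4 (0.43 log units; beyond the scatter), smaller than the step to the sulfamoyl of compound 1. Compound 4 is expected at 400 nM, between 150 nM and 1200 nM.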

Compound 4, half-maximal effective concentration: 2900 nM
For compound 4 the middle estimate is 7.3-fold (0.86 log units) below the measured one, and the stated range ends below it.
By their numbers in this assay, from the lowest: compound 3; then compound 2; then compound 1; then compound 4.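

In this assay, within the data shown here, acetamido gives the largest step seen at this aromatic carbon, with a 19-fold higher number from compound 3 to compound 4 (1.29 log units; beyond the scatter) against methoxy, so a change at this position can cost far more than the earlier compounds indicated. Acetamido also stands above both other groups, with an 8.3-fold higher number from compound 2 to compound 4 (0.92 log units; beyond the scatter) from 2-carboxyethyl and a 2.1-fold higher number from compound 1 to compound 4 (0.32 log units; beyond the scatter) from sulfamoyl, so the range at this position is wider than the three earlier compounds showed. Size and hydrogen-bond donor change together in this exchange, and no available data account for the step.

Going by these compounds, whether the rise follows the amide hydrogen or the larger size of acetamido remains open; an amine, a hydroxyl or a propionamido group at this aromatic carbon would bear on that. Also open, on these data alone, is whether a group smaller than methoxy, such as fluorine or a bare hydrogen, would lower the number further.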